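Amide nitrogen substituent and lipophilicity in the dihydrobenzofuran amides

A few compounds are considered here, and "the series" means these few. Any claim that something is new, unique, unknown or untested is made for them only; others in the source may bear on it.

Three compounds of the series have a lipophilicity reading. Compound 1 `CNC(=O)c1cc(C(=O)N[C@H]2[C@@H]3COC[C@@H]32)cc2c1OC[C@H]2c1ccccc1` gives, in a physicochemical assay for lipophilicity, at pH 7.4 (on this read-out higher numbers stand for higher lipophilicity and lower numbers for lower lipophilicity), a value of 3.3. Compound 2 `CNC(=O)c1cc(C(=O)NC2CC2)cc2c1O[C@H](CF)[C@H]2c1ccccc1` gives in this assay 3.9. For the measured compounds named here, compound 3 `CNC(=O)c1cc(C(=O)N[C@H]2CC[C@H](O)CC2)cc2c1OC[C@@]2(C)c1ccccc1` gives in this assay 3.3, which is level with compound 1 within the scatter; together these two are the lowest of the three readings, and the reading of compound 2 is the one furthest from compound 3, lying higher by more than the scatter.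

Compound 4 `CNC(=O)c1cc(C(=O)NC)c2c(c1)[C@](C)(c1ccccc1)CO2` has not been measured in this assay. It differs from compound 3 in one place: methyl in place of 4-hydroxycyclohexyl on an amide-type nitrogen. Going by the values given here, no measured pair in the set carries this same change, so the expected step rests on the change itself. With the 4-hydroxycyclohexyl group leaving and only a methyl entering, a modest decrease, somewhat beyond the scatter, is expected; the step from compound 3 to compound 4 is estimated at a number 0.40 log units lower from compound 3 to compound 4 (beyond the scatter). Compound 4 is therefore expected to give in this assay about 2.9, within a range of 2.5 to 3.3.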

Compound 4, distribution coefficient: 3.4
For compound 4 the middle estimate is 0.50 log units below the measured one; measured number outside the range, above it.
By their numbers in this assay, from the lowest: compounds 1, 3 and 4 (each within the scatter of the next); then compound 2.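

For the compounds shown here, the first pair that differs in one place gives a direct reading on the amide-type nitrogen: in this assay, methyl in place of 4-hydroxycyclohexyl gives a number 0.10 log units higher from compound 3 to compound 4 (within the scatter). The six-membered ring and the hydroxyl thus leave together, and the two compounds still read level, a result that compounds 1 and 2, which differ from compound 3 in more than one place, could not show. No measurement shown accounts for this level reading.

The compounds shown leave open what the ring and the hydroxyl each contribute, since they only ever leave together; a plain cyclohexyl on the same nitrogen would separate them. Also open, from the compounds shown here alone, is whether the level reading holds for groups of another kind at this nitrogen, such as an amine-bearing chain or a carboxylic acid.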